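A few compounds are considered here, and "the series" means these few. Any claim that something is new, unique, unknown or untested is made for them only; others in the source may bear on it.

Measured so far in an ADME assay on Vero cells (Chlorocebus sabaeus) for cytotoxicity, with a stated time of 72 h (on this read-out lower numbers stand for stronger inhibition and higher numbers for weaker inhibition), each value a limit of the assay and not a number:
Compound 1 (`CCOC(=O)c1cc(/C=C/c2cccc(C)c2)on1`) reads > 128000 nM as a limit.
Compound 2 (`CCOC(=O)c1cc(/C=C/c2cc(F)cc(F)c2)on1`) reads > 128000 nM as a limit.
Compound 3 (`CCOC(=O)c1cc(/C=C\c2cccc([N+](=O)[O-])c2)on1`) reads > 128000 nM as a limit.

The whole set stands at the limit of > 128000 nM in this assay, at which 3 of the 3 values shown sit, so compound 1 has only a limit and no number of its own. Among the compounds with values here, no order among the three can be read, and no measured step between them is available to size a new change.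

The next compound to be read in this assay is compound 4 (`CCOC(=O)c1cc(/C=C/c2cccc(O)c2)on1`). It carries hydroxy in place of methyl on an aromatic carbon, meta to a large group (hydroxy in place of methyl on an aromatic carbon).

No shift beyond the scatter is expected from this change, and any movement should be small and towards stronger inhibition. Aromatic substitution different from that of compound 1 still leaves compound 2 at the limit > 128000 nM, and this is the ground for the expectation. The expected size of the change is an at least 1.0-fold lower number from compound 1 to compound 4 (0.02 log units; that floor lies within the scatter), which is an estimate and may not be resolved if only a limit comes back. Compound 4 is estimated at 120000 nM, with an expected range from 55000 nM to 128000 nM, and a reading at the limit is the likeliest outcome.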

Compound 4, half-maximal inhibitory concentration: > 128000 nM
Compound 4: a limit, no number (the forecaster's own chance of this, stated with the estimate: 70%); at least 1.0-fold (0.02 log units) between middle value and limit.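

In this assay, compound 4 and compound 1 both return only a limit, so no step from compound 1 to compound 4 can be read: the limit of > 128000 nM in this assay, at which 4 of the 4 values shown sit.

The compounds shown leave open what number any of them would give in this assay, and whether hydroxy in place of methyl on an aromatic carbon shifts it at all.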